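The source may hold more compounds than are shown below. What is called first, only, known or untested is meant among the compounds shown, and "the series" means these compounds.

Measured so far:
compound 1 `Nc1nc(O)c2ncn([C@@H]3C=C4C[C@](CC(=O)O)(C(=O)O)O[C@H]4[C@H]3O)c2n1` — 1000 nM
compound 2 `Nc1nc(O)c2ncn([C@@H]3C[C@H]4C[C@](CC(=O)O)(C(=O)O)O[C@H]4C3)c2n1` — 340 nM

Both numbers come from an assay for inhibition of phosphodiesterase 1 (Bos taurus), read by cGMP accumulation; a higher number here means a weaker inhibitor, a lower number a stronger inhibitor. Compound 2 gives the lower of the two values, and its gap to compound 1 is beyond the usual scatter, so compound 2 is the stronger inhibitor of the pair.

Compound 3, `O=C(O)C[C@]1(C(=O)O)C[C@@H]2C[C@@H](n3cnc4c(O)ncnc43)C[C@@H]2O1`, has not yet been measured in this assay. It differs from compound 2 in one place: hydrogen in place of amino on an aromatic carbon. Among the measured compounds shown here, no measured pair of compounds shows what this change does to the numbers, so the expectation rests on the change alone. A modest move toward weaker inhibition seems the more likely outcome, although a result within the scatter of compound 2 would not be surprising. For compound 3 the expected step is a 2.1-fold higher number from compound 2 to compound 3 (0.31 log units; beyond the scatter). The estimate for compound 3 is therefore 700 nM, with a range from 250 nM to 2000 nM.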

Compound 3, half-maximal inhibitory concentration: 9000 nM
The estimate for compound 3 lay 13-fold (1.11 log units) below the measured number; the whole stated range lies below it.
By their numbers in this assay, from the lowest: compound 2; then compound 1; then compound 3.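

In this assay, putting hydrogen in place of amino on the aromatic carbon between two ring nitrogen atoms gives a 26-fold higher number from compound 2 to compound 3 (1.42 log units; beyond the scatter), a large step toward weaker inhibition. Among the compounds shown here, this is the first pair of compounds differing only at this position, and it shows that, on this core, inhibition depends strongly on the amino group being there. Nothing measured here explains why removing it costs so much.

From the compounds shown here alone, it remains open whether a small replacement such as methylamino, methyl or chlorine on the same carbon would keep the inhibition of compound 2 or lose it as compound 3 does. Going by these compounds, it is also open whether removing amino would cost as much on the core of compound 1.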